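Sulfamoyl in Place of Chloro on the Urea Phenyl

The source may hold more compounds than are shown below. What is called first, only, known or untested is meant among the compounds shown, and "the series" means these compounds.

Compound 1, `O=C(Nc1cccc(-c2nc(-c3ccc(NC(=O)c4cccnc4)cc3Cl)no2)c1)c1ccccc1`: 12800 nM in a functional assay on MDA-MB-231 cells (Homo sapiens) for antiproliferative activity, read by MTT assay, with a stated time of 72 h; a higher number here means a weaker inhibitor, a lower number a stronger inhibitor
Compound 2, `O=C(Nc1ccc(Cl)cc1)Nc1cccc(-c2nc(-c3ccc(NC(=O)c4cccnc4)cc3Cl)no2)c1`: > 10000 nM in this assay

Compound 1 is a weak inhibitor in this assay. For compound 2 the assay reports only a limit, not a number, and compound 2 therefore stands at the edge of what this assay can read. For the measured compounds named here, the single measured step, a step that the limit leaves unreadable from compound 1 to compound 2, is accordingly of unreadable size, which follows from the limit of > 10000 nM in this assay, at which 1 of the 2 values shown sits.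

Compound 3, `NS(=O)(=O)c1ccc(NC(=O)Nc2cccc(-c3nc(-c4ccc(NC(=O)c5cccnc5)cc4Cl)no3)c2)cc1`, differs from compound 2 by sulfamoyl in place of chloro on an aromatic carbon. Going by the values given here, no measured step touches this exchange: the one step in hand is unreadable, and nothing in the measured pair separates the effect of the urea phenyl substituent from that of the urea itself. What compound 2 shows is that the limit already holds there, so compound 3 is expected to sit near the same limit, with a step that the limit leaves unreadable from compound 2 to compound 3 that is expected to stay within the scatter. Compound 3 is estimated at 15000 nM, with a range from 4000 nM to 60000 nM, and a good chance that the assay again reports only a limit.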

Compound 3, half-maximal inhibitory concentration: > 10000 nM
Compound 3 ended at the assay's limit; the forecaster's own chance of this, stated with the estimate: 60%; the middle value lies beyond the limit too.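

In this assay compound 3 gives > 10000 nM, a limit and not a number. No step linking compound 3 to compound 1 or compound 2 can therefore be read: the limit of > 10000 nM in this assay, at which 2 of the 3 values shown sit.

The compounds shown leave open whether sulfamoyl in place of chloro changes activity at all, and how compound 2 and compound 3 truly compare with compound 1.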